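From methyl to tert-butyl in compound 2

A few compounds are considered here, and "the series" means these few. Any claim that something is new, unique, unknown or untested is made for them only; others in the source may bear on it.

Values from a physicochemical assay for solubility, using potentiometric titration; on this read-out lower numbers stand for lower solubility and higher numbers for higher solubility:
Compound 1 `Fc1ccc(-c2nc(-c3ccc(-c4ccccc4)cc3)no2)cc1F`: 16000 nM
Compound 2 `Cc1ccc(-c2noc(-c3ccc(F)c(F)c3)n2)cc1`: 35000 nM

Of these two compounds, compound 2 holds the higher number, and the gap to compound 1 lies beyond the usual scatter. Compound 3 `CC(C)(C)c1ccc(-c2noc(-c3ccc(F)c(F)c3)n2)cc1` keeps the core of compound 2 and changes one group: tert-butyl in place of methyl on an aromatic carbon. Tert-butyl takes the place of methyl on an aromatic carbon, para to a large group.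

Among the compounds with values here, only one measured step bears on this: a 2.2-fold higher number from compound 1 to compound 2 (0.34 log units; beyond the scatter). It was modest, and it came when methyl replaced phenyl. Compound 3 also gives up methyl, this time for tert-butyl rather than phenyl, so a modest move towards a lower number is expected in this assay. One step is thin evidence, so the range stays wide. The estimated change is a 2.1-fold lower number from compound 2 to compound 3 (0.31 log units; beyond the scatter). For compound 3 the estimated value is 17000 nM, with an expected range from 7000 nM to 38000 nM.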

Compound 3, solubility: 91000 nM
Beside the measured number, compound 3's estimate is 5.4-fold (0.73 log units) below it, and the stated range ends below it.
By their numbers in this assay, from the lowest: compound 1; then compound 2; then compound 3.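

In this assay, replacing methyl with tert-butyl on this aromatic carbon gives a 2.6-fold higher number from compound 2 to compound 3 (0.41 log units; beyond the scatter) and replacing phenyl with tert-butyl gives a 5.7-fold higher number from compound 1 to compound 3 (0.75 log units; beyond the scatter) at the same place. The earlier step therefore did not mean that moving away from methyl must lower the number: of the three groups at this position, tert-butyl carries the highest value, and the order does not follow a simple path from methyl upward in group size. Nothing measured alongside these numbers accounts for this result.

The compounds shown leave open whether ethyl or isopropyl would fall between methyl and tert-butyl. They also leave open how an amine or a carboxylic acid at this position would compare with these three groups.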